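The source may report more compounds than this note shows. Statements on the series, on what has been measured and on what is new or still open speak of the compounds shown alone.

Measured in a functional assay on cells for antagonist activity at C-X-C chemokine receptor type 4 (Homo sapiens), read by fluorescence and calcium flux, with stated times of 25 min and 90 s; on this read-out higher numbers stand for weaker inhibition and lower numbers for stronger inhibition:
compound 1, `c1ccc2c(c1)CN[C@@H](CN(CCCCNC1CCNCC1)[C@H]1CCCc3cccnc31)C2`: 63.4 nM
compound 2, `c1ccc2c(c1)CN[C@@H](CN(CCCCNC1CCSCC1)[C@H]1CCCc3cccnc31)C2`: 54.7 nM
compound 3, `CC(C)(CN)CCN(C[C@H]1Cc2ccccc2CN1)[C@H]1CCCc2cccnc21`: 69 nM

Compound 3 sits within the scatter of both other compounds: the step of a 1.1-fold higher number from compound 1 to compound 3 (0.04 log units; within the scatter) and the step of a 1.3-fold higher number from compound 2 to compound 3 (0.10 log units; within the scatter) are each inside the usual spread, as is a 1.2-fold lower number from compound 1 to compound 2 (0.06 log units; within the scatter). Compound 4, `C(=C/CN(C[C@H]1Cc2ccccc2CN1)[C@H]1CCCc2cccnc21)\CNCC1CCOCC1`, differs from compound 3 by a group of 11 heavy atoms (9 carbon, 1 nitrogen, 1 oxygen; one six-membered non-aromatic ring with 1 hetero atom) in place of a group of 6 heavy atoms (5 carbon, 1 nitrogen; no ring), on a saturated chain carbon bound to an amine nitrogen. Among the compounds with values here, the steps that bear on this are those among compounds 1, 2 and 3, which exchanged a ring-bearing group for a ring-free one on the chain two bonds from an amine nitrogen without moving the number beyond the scatter. Within the data shown here, the change to compound 4 again brings in a ring-bearing group in place of a ring-free one, now carrying a double bond outside aromatic rings and an oxygen in the ring; no measured pair speaks to the double bond or to the oxygen. The expected step is therefore none beyond the scatter, with a wider range to cover the untested features. For compound 4 the estimate in this assay is 65 nM, between 25 nM and 170 nM. The expected step is a 1.1-fold lower number from compound 3 to compound 4 (0.03 log units; within the scatter).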

Compound 4, half-maximal inhibitory concentration: 24.2 nM
Estimate against measurement, compound 4: 2.7-fold (0.43 log units) above; measured number outside the range, below it.
By their numbers in this assay, from the lowest: compound 4; then compounds 2, 1 and 3 (each within the scatter of the next).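

In this assay, within the data shown here, the change on a saturated chain carbon bound to an amine nitrogen is the first here to move the number beyond the scatter (a 2.9-fold lower number from compound 3 to compound 4 (0.46 log units; beyond the scatter)), and the steps against the two ring-bearing compounds are also modest and beyond the scatter (a 2.3-fold lower number from compound 2 to compound 4 (0.35 log units; beyond the scatter); a 2.6-fold lower number from compound 1 to compound 4 (0.42 log units; beyond the scatter)). Among these compounds, the earlier steps among compounds 1, 2 and 3 all stayed within the scatter, so this result is the first sign that the group carried on the amine nitrogen can shift the number, and the ring-bearing group of compound 4 gives the lowest number of the four. Nothing available accounts for the shift.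

Compound 4 brings in the double bond and the ring oxygen together, and the compounds shown do not separate the two. Also open, on these data alone, is how a saturated chain carrying the same oxygen-bearing ring, or a morpholine ring in its place, would read.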